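A few compounds are considered here, and "the series" means these few. Any claim that something is new, unique, unknown or untested is made for them only; others in the source may bear on it.

Compound 3 `COc1cccc(-c2cc(COC(Cc3cn(C4CCN(Cc5ccc([N+](=O)[O-])cc5)CC4)nn3)c3ccc(Br)cc3)on2)c1` gives 7000 nM in a functional assay on MCF7 cells (Homo sapiens) for cytotoxicity, with a stated time of 48 h (a higher number here means a weaker inhibitor, a lower number a stronger inhibitor), level with compound 1 `O=[N+]([O-])c1ccc(CN2CCC(n3cc(CC(OCc4cc(-c5ccc(F)cc5)no4)c4ccc(Br)cc4)nn3)CC2)cc1`, which gives 7000 nM in this assay; compound 2 `O=[N+]([O-])c1ccc(CN2CCC(n3cc(CC(OCc4cc(-c5cccc(F)c5)no4)c4ccc(Br)cc4)nn3)CC2)cc1` gives 8000 nM. Compound 3 thus shares with compound 1 the lowest number of the three, nearest compound 1 and furthest from compound 2, though all three sit within the scatter of one another. Compound 4 `O=[N+]([O-])c1ccc(CN2CCC(n3cc(CC(OCc4cc(-c5ccccc5Br)no4)c4ccc(Br)cc4)nn3)CC2)cc1` differs from compound 3 in one place: 2-bromophenyl in place of 3-methoxyphenyl on an aromatic carbon. The measured steps that bear on this swap all stay within the scatter: a 1.1-fold higher number from compound 1 to compound 2 (0.06 log units; within the scatter), no change at the digits printed from compound 1 to compound 3 (within the scatter) and a 1.1-fold lower number from compound 2 to compound 3 (0.06 log units; within the scatter). Among the compounds with values here, since no change of the aryl group on the five-membered ring has moved the number beyond the scatter, compound 4 is expected to show no step of note, with no change at the digits printed from compound 3 to compound 4 (within the scatter). The estimated value for compound 4 is 7000 nM, within a range of 3500 nM to 14000 nM.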

Compound 4, half-maximal inhibitory concentration: 6000 nM
The estimate for compound 4 lay 1.2-fold (0.07 log units) above the measured number, within the range that was stated.
By their numbers in this assay, from the lowest: compounds 4, 1, 3 and 2 (each within the scatter of the next).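

In this assay the 2-bromophenyl group gives a 1.2-fold lower number from compound 3 to compound 4 (0.07 log units; within the scatter) and a 1.3-fold lower number from compound 2 to compound 4 (0.12 log units; within the scatter) and a 1.2-fold lower number from compound 1 to compound 4 (0.07 log units; within the scatter) with no step beyond the scatter. The aryl groups on this aromatic carbon of the five-membered ring, so far fluoro- and methoxy-bearing, now include a bromine-bearing one, and the number still holds level with them. No evidence is at hand to explain this flat response. The compounds shown leave open how the number would respond if an amine, a carboxylic acid or a longer chain stood in place of the aryl group.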